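This account rests on a few compounds, and the source may have more. Where it says the series, first, only, none or still open, it means among the compounds named here.

Compound 1 `C=CC(=O)Nc1cccc(NC(=O)CSc2nc(Nc3ccccc3Br)c3ccccc3n2)c1` gives 15200 nM in a functional assay on MDA-MB-231 cells (Homo sapiens) for inhibition, read by MTT assay, with a stated time of 72 h; on this read-out lower numbers stand for stronger inhibition and higher numbers for weaker inhibition; compound 2 `C=CC(=O)Nc1cccc(NC(=O)CSc2nc(Nc3ccccc3C)c3ccccc3n2)c1` gives 20400 nM, and compound 3 `C=CC(=O)Nc1cccc(NC(=O)CSc2nc(Nc3cccc(C)c3)c3ccccc3n2)c1` gives 16800 nM. Compound 3 stands second highest of these three numbers, nearest to compound 1 and furthest from compound 2; both gaps, a 1.1-fold higher number from compound 1 to compound 3 (0.04 log units; within the scatter) and a 1.2-fold lower number from compound 2 to compound 3 (0.08 log units; within the scatter), lie within the scatter, as does a 1.3-fold higher number from compound 1 to compound 2 (0.13 log units; within the scatter). Compound 4 `C=CC(=O)Nc1cccc(NC(=O)CSc2nc(Nc3cccc(OC)c3)c3ccccc3n2)c1` differs from compound 3 by methoxy in place of methyl on an aromatic carbon. Among the measured compounds shown here, no measured step exchanges methyl for methoxy; the three steps that alter this ring all stay within the scatter, so no movement beyond the scatter in this assay is expected here either. Compound 4 is therefore estimated at 17000 nM, with a range of 8000 nM to 36000 nM. The step expected, a 1.0-fold higher number from compound 3 to compound 4 (0.01 log units; within the scatter), sits within the scatter.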

Compound 4, half-maximal inhibitory concentration: 12900 nM
Compound 4: middle estimate off by 1.3-fold (0.12 log units), on the high side, and the stated range covers the measured number.
By their numbers in this assay, from the lowest: compounds 4, 1, 3 and 2 (each within the scatter of the next).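

Methoxy in place of methyl on this aromatic carbon adds an oxygen and a hydrogen-bond acceptor, yet a 1.3-fold lower number from compound 3 to compound 4 (0.11 log units; within the scatter) in this assay shows no movement beyond the scatter. The steps of a 1.6-fold lower number from compound 2 to compound 4 (0.20 log units; within the scatter) and a 1.2-fold lower number from compound 1 to compound 4 (0.07 log units; within the scatter) also stay within the scatter, so bromo, methyl and methoxy on this ring all leave the four compounds on one level. No supporting data bear on this result. From the compounds shown here alone, whether an amine, a carboxylic acid or a longer alkoxy chain here would move the number beyond the scatter remains open.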